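The source may hold more compounds than are shown below. What is called first, only, known or untested is meant among the compounds shown, and "the series" means these compounds.

Measured in a functional assay on A549 cells (Homo sapiens) for antiproliferative activity, read by sulforhodamine B assay, with a stated time of 3 days; on this read-out higher numbers stand for weaker inhibition of growth and lower numbers for stronger inhibition of growth:
Compound 1 `COc1ccc(NC(=O)c2cccc(Nc3ncc(F)c(Nc4ccc(F)cc4)n3)c2)cc1`: 11000 nM
Compound 2 `O=C(c1cccc(Nc2ncc(F)c(Nc3ccc(F)cc3)n2)c1)N1CCCCC1`: 13200 nM
Compound 3 `O=C(Nc1cccc(Nc2ncc(F)c(Nc3ccc(F)cc3)n2)c1)c1cccc([N+](=O)[O-])c1`: 7250 nM

In this assay compound 3 gives 7250 nM, which lies within the scatter of the values of compound 1 and compound 2, so it stands apart from neither. Compound 4 `O=C(Nc1cccc(Nc2ncc(F)c(Nc3ccc(F)cc3)n2)c1)c1ccccc1` differs from compound 3 by hydrogen in place of nitro on an aromatic carbon. Within the data shown here, the only measured step, a 1.2-fold higher number from compound 1 to compound 2 (0.08 log units; within the scatter), is a change at a carbonyl carbon, not at this place, so it bears on this change only indirectly. No step beyond the scatter is therefore expected, and no direction can be argued. The expected change is a 1.2-fold higher number from compound 3 to compound 4 (0.09 log units; within the scatter). Compound 4 is estimated at 9000 nM, with an expected range of 4000 nM to 20000 nM.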

Compound 4, concentration for 50% growth inhibition: 37800 nM
Compound 4: middle estimate off by 4.2-fold (0.62 log units), on the low side; the whole stated range lies below it.
By their numbers in this assay, from the lowest: compounds 3, 1 and 2 (each within the scatter of the next); then compound 4.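

In this assay, among these compounds, this aromatic carbon proves sensitive to its substituent: hydrogen in place of nitro gives a 5.2-fold higher number from compound 3 to compound 4 (0.72 log units; beyond the scatter), whereas the only earlier step stayed within the scatter. The nitro-free benzamide also separates from the other two amides, with a 2.9-fold higher number from compound 2 to compound 4 (0.46 log units; beyond the scatter) and a 3.4-fold higher number from compound 1 to compound 4 (0.54 log units; beyond the scatter). No measurement at hand accounts for these steps.

From the compounds shown here alone, whether an amine or a nitrile on this aromatic carbon would give a value nearer compound 3 or compound 4 stays open, as does the effect of moving the nitro elsewhere on its ring.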